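Shortening the amide chain in the cinnamamide series

The source may hold more compounds than are shown below. What is called first, only, known or untested is meant among the compounds shown, and "the series" means these compounds.

Three cinnamoyl derivatives have numbers in a functional assay on the whole organism for inhibition, with Brassica rapa subsp. chinensis as the target, with a stated time of 3 days, tested at 100 ppm (a higher number here means more inhibition of growth at the concentration tested, a lower number less inhibition of growth), so far. Compound 1 `CCCCCCCCCCCCCCCCNC(=O)/C=C/c1ccccc1` gives 20% in this assay, the lowest of the three. Compound 3 `CC(C)=CCCC(C)CCOC(=O)/C=C/c1ccc(C(C)C)cc1` gives 39% in this assay, a number beyond the scatter above compound 1, and compound 2 `C=CCc1ccc(OC(=O)/C=C/c2ccc(C(C)C)cc2)c(OC)c1` gives 40% in this assay, also beyond the scatter above compound 1. Compound 2 and compound 3 share an ester link and the same aryl part, while compound 1 carries an amide and an unsubstituted phenyl ring, so the gap between them cannot be assigned to any single change. Within the data shown here, no pair of measured compounds differs in one place only.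

Compound 4 `CCCCCCCCNC(=O)/C=C/c1ccccc1` keeps the core of compound 1 and differs from it by hydrogen in place of octyl on a saturated chain carbon, eight bonds along the chain from an amide-type nitrogen; the same difference, cut one bond further out, reads nonyl to methyl. Among the measured compounds shown here, no measured step in this assay concerns chain length, and the two esters offer no guidance on the amide chain. The step from compound 1 to compound 4 in this assay is therefore expected to be small, a number 5 percentage points higher from compound 1 to compound 4 (within the scatter), without a clear direction beyond the scatter. Compound 4 is estimated at 25% in this assay, with a range from 5% to 50%.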

Compound 4, percent growth inhibition at one concentration: 34%
For compound 4 the middle estimate is 9 percentage points below the measured one; measured number inside the range.
By their numbers in this assay, from the lowest: compound 1; then compounds 4, 3 and 2 (each within the scatter of the next).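

In this assay the series now has its first readable step at the amide chain: hydrogen in place of octyl on a saturated chain carbon, eight bonds along the chain from an amide-type nitrogen, gives a number 14 percentage points higher from compound 1 to compound 4 (beyond the scatter). At this position, the outer octyl part of the chain in compound 1 is therefore not required for growth inhibition at the concentration tested, and with the core of compound 1 unchanged, the shorter chain in compound 4 gives the higher number. No measurement available on these compounds accounts for the step, so it stands as an observation on this single pair.

From the compounds shown here alone, a single step between two chain lengths gives no trend, so it remains open whether a butyl chain would continue the direction seen here, and whether a dodecyl chain would fall on the line between compound 1 and compound 4 or off it. Also open, going by these compounds, is how a terminal amine or a carboxylic acid at the chain end would compare with the plain saturated chain of compound 4.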